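This account rests on a few compounds, and the source may have more. Where it says the series, first, only, none or still open, it means among the compounds named here.

Measured so far:
compound 1 `Cc1ccc2c(=O)cc(-c3ccc(F)cc3)oc2c1` — "not active" (no number reported)
compound 2 `COc1ccc(-c2cc(=O)c3ccc(F)cc3o2)cc1` — 40%

Of the compounds shown here, two that share one core have been tested in an in vitro assay on BTI-TN-5B1-4 cells for inhibition of Amine oxidase [flavin-containing] A (Homo sapiens), tested at 100 uM; a higher number here means more inhibition at the concentration tested (going by the name of the read-out), a lower number less inhibition. Compound 1 `Cc1ccc2c(=O)cc(-c3ccc(F)cc3)oc2c1` is reported only as "not active" (no number reported), with no number attached. Compound 2 `COc1ccc(-c2cc(=O)c3ccc(F)cc3o2)cc1` gives 40%; this is the only number shown for this assay, the other entry carrying no single value. Compound 3 `COc1ccc(-c2cc(=O)c3ccc(C)cc3o2)cc1` has not yet been measured. It differs from compound 2 in one place: methyl in place of fluoro on an aromatic carbon. Going by the values given here, no step between two measured compounds is available to show what such a change does on this core, so the size of the step in this assay can only be guessed. A small drop, or nothing beyond the usual scatter, seems most plausible; the step is estimated at a number 10 percentage points lower from compound 2 to compound 3 (within the scatter). Compound 3 is expected to give 30%, with a likely range from 5% to 60%.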

Compound 3, a percentage reported as inhibition, at one concentration (the size of the read-out at that concentration, not a potency): 40%
Compound 3: middle estimate off by 10 percentage points, on the low side; the range from low to high includes it.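

In this assay, going by these compounds alone, putting methyl in place of fluoro on this aromatic carbon gives no change at the digits printed from compound 2 to compound 3 (within the scatter), the first step on the shared core that can be read. At this position, on a six-membered aromatic ring of carbon only that is part of a fused system, the read-out therefore does not separate these two groups, each of one heavy atom. No measurement shown here bears on what lies behind this result.

On these data alone, what an amine, a carboxylic acid or a longer chain would do at this same position remains open. Also open, as far as these compounds go, is whether fluoro and methyl would still read alike at other concentrations, since a single concentration shows the size of the read-out and not a potency.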